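A few compounds are considered here, and "the series" means these few. Any claim that something is new, unique, unknown or untested is made for them only; others in the source may bear on it.

Measured so far in an assay on isolated protein for inhibition of D(1B) dopamine receptor (Homo sapiens); on this read-out lower numbers stand for stronger inhibition and higher numbers for weaker inhibition:
- compound 1, `CC(C)(C)OC(=O)NCC#Cc1ccc2c(c1)C=C([N+](=O)[O-])C(C(F)(F)F)O2`, 1250 nM
- compound 2, `O=C(O)c1ccc(C#Cc2ccc3c(c2)C=C([N+](=O)[O-])C(C(F)(F)F)O3)cc1`, 2100 nM
- compound 3, `CC(C)(C)C#Cc1ccc2c(c1)C=C([N+](=O)[O-])C(C(F)(F)F)O2`, 2100 nM

Compound 3 sits level with compound 2 at the digits shown; together these are the two highest numbers of the three, and compound 1 lies a short way under them, a 1.7-fold higher number from compound 1 to compound 3 (0.23 log units; within the scatter), a step within the scatter, as are a 1.7-fold higher number from compound 1 to compound 2 (0.23 log units; within the scatter) and no change at the digits printed from compound 2 to compound 3 (within the scatter). For the measured compounds named here, no step among the three reaches beyond the scatter: the three substituents on the triple-bonded carbon give essentially one number in this assay.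

Compound 4, `CC(=O)NCC#Cc1ccc2c(c1)C=C([N+](=O)[O-])C(C(F)(F)F)O2`, is not yet measured. The change from compound 3 is acetamidomethyl in place of tert-butyl on a triple-bonded carbon. The step that bears on it most directly is a 1.7-fold higher number from compound 1 to compound 3 (0.23 log units; within the scatter): compound 1 carries a ((tert-butoxycarbonyl)amino)methyl group on the same triple-bonded carbon, a group that, like acetamidomethyl, holds an amide hydrogen and a carbonyl, and that step stayed within the scatter. no change at the digits printed from compound 2 to compound 3 (within the scatter) shows the same for 4-carboxyphenyl. On this basis no step beyond the scatter is expected in this assay; if anything a slightly lower number is expected for compound 4, about a 1.5-fold lower number from compound 3 to compound 4 (0.18 log units; within the scatter). Compound 4 is therefore estimated at 1400 nM, with a range from 600 nM to 3500 nM.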

Compound 4, inhibition constant: 1100 nM
Compound 4: the middle estimate sits 1.3-fold (0.10 log units) above what was measured; low and high end bracket the measured number.
By their numbers in this assay, from the lowest: compounds 4, 1, 2 and 3 (each within the scatter of the next).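

In this assay, acetamidomethyl on the triple-bonded carbon stays within the scatter of both tert-butyl (a 1.9-fold lower number from compound 3 to compound 4 (0.28 log units; within the scatter)) and 4-carboxyphenyl (a 1.9-fold lower number from compound 2 to compound 4 (0.28 log units; within the scatter)), so this position has now taken a fourth group, one with an amide hydrogen and a carbonyl, without a step beyond the scatter. The new pair also isolates a change further out on the substituent: methyl in place of tert-butoxy on the carbonyl carbon leaves the number within the scatter (a 1.1-fold lower number from compound 1 to compound 4 (0.06 log units; within the scatter)), so the tert-butoxy end of compound 1 is not needed to hold this read-out, and all four compounds remain one group of numbers with no order among them. No measurement shown here bears on why these substituents give such similar numbers.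

Still open, as far as these compounds go, is whether a free aminomethyl group, a carboxylic acid on a short chain or a longer chain at the triple-bonded carbon would produce a step beyond the scatter. The same question stands for changes to the shared core, since all four compounds carry it unchanged and this flat response is known only for this assay.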